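The source may hold more compounds than are shown below. What is called first, only, known or untested is meant among the compounds shown, and "the series" means these compounds.

Measured compounds in a functional assay on SW-620 cells (Homo sapiens) for antiproliferative activity, read by MTT assay, with a stated time of 72 h; on this read-out higher numbers stand for weaker inhibition and lower numbers for stronger inhibition:
- compound 1 `O=C1O[C@H]([C@@H](O)Cn2cc(CNS(=O)(=O)c3ccc(F)cc3)nn2)C(OCc2ccccc2)=C1OCc1ccccc1` gives 41100 nM.
- compound 2 `CCCCCc1ccc(-c2cn(C/C=C3\OC(=O)C(OCc4ccccc4)=C3OCc3ccccc3)nn2)cc1` reaches only the assay limit, > 100000 nM.
- compound 3 `CC(C)(C)OC(=O)N1CCN(C(=S)SCc2cn(C[C@H](O)[C@H]3OC(=O)C(OCc4ccccc4)=C3OCc3ccccc3)nn2)CC1` likewise reaches only the assay limit, > 100000 nM.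

Among the compounds with values here, compound 1 holds the only numerical value in this assay; the other two entries sit at the limit of > 100000 nM in this assay, at which 2 of the 3 values shown sit, and give no number to compare against. Within the data shown here, no pair of measured compounds differs in a single place, so no step size is established.

Compound 4 `O=C1O[C@H]([C@@H](O)Cn2cc(CNS(=O)(=O)c3ccc(Cl)cc3)nn2)C(OCc2ccccc2)=C1OCc1ccccc1` differs from compound 1 by chloro in place of fluoro on an aromatic carbon. For a change of this kind, no step beyond the usual scatter is expected in this assay. Compound 4 is therefore estimated at 30000 nM, spanning 10000 nM to 100000 nM, an expected step of a 1.4-fold lower number from compound 1 to compound 4 (0.14 log units; within the scatter).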

Compound 4, half-maximal inhibitory concentration: 18000 nM
The estimate for compound 4 lay 1.7-fold (0.22 log units) above the measured number; low and high end bracket the measured number.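

In this assay, within the data shown here, the exchange of 4-fluorophenyl for 4-chlorophenyl gives the first readable step: a 2.3-fold lower number from compound 1 to compound 4 (0.36 log units; beyond the scatter). This aromatic position therefore responds to a swap of one halogen for another, though only modestly, and the core of compound 1 is unchanged. Compound 2 and compound 3 offer no comparison with this step, since each differs from it in more than one place and each is a limit: the limit of > 100000 nM in this assay, at which 2 of the 4 values shown sit.

Open, from the compounds shown here alone, is whether bromo, methyl or an amino group on the same aromatic carbon would move the number further. Also open, going by these compounds, is whether hydrogen there would fall nearer compound 1 or compound 4.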